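From Carbamate Back to a Free Amine

This account rests on a few compounds, and the source may have more. Where it says the series, first, only, none or still open, it means among the compounds named here.

compound 1 `CC[C@H](C)C(N)c1cc(C(F)(F)F)ccc1N1CCN(C(=O)CCc2ccc(Cl)cc2Cl)CC1`: 75 nM
compound 2 `CCC(C)[C@H](NC(=O)OC)c1cc(C(F)(F)F)ccc1N1CCN(C(=O)CCc2ccc(Cl)cc2Cl)CC1`: 2400 nM

Both numbers come from an assay on HEK293 cells for displacement of a labelled ligand from Melanocortin receptor 4 (Homo sapiens); a higher number here means a weaker inhibitor, a lower number a stronger inhibitor. Among the compounds with values here, compound 2 stands highest of the two, with compound 1 its only neighbour, far below it. Within the data shown here, the single measured step, a 32-fold higher number from compound 1 to compound 2 (1.51 log units; beyond the scatter), is large. Compound 3 `CN[C@@H](CC(C)C)c1cc(C(F)(F)F)ccc1N1CCN(C(=O)CCc2ccc(Cl)cc2Cl)CC1` differs from compound 2 by 3-methyl-1-(methylamino)butyl in place of 1-((methoxycarbonyl)amino)-2-methylbutyl on an aromatic carbon. This removes the methoxycarbonyl cap and restores an amine bearing a hydrogen on nitrogen, as in compound 1, so the step is expected to run opposite to a 32-fold higher number from compound 1 to compound 2 (1.51 log units; beyond the scatter) and be large, a 24-fold lower number from compound 2 to compound 3 (1.38 log units; beyond the scatter). Compound 3 is therefore expected to give 100 nM, in a range from 30 nM to 400 nM.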

Compound 3, inhibition constant: 1900 nM
Compound 3: the middle estimate sits 19-fold (1.28 log units) below what was measured; measured number above the stated range.
By their numbers in this assay, from the lowest: compound 1; then compounds 3 and 2 (each within the scatter of the next).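

Losing the methoxycarbonyl cap does not by itself bring back the binding of compound 1: the change gives a 1.3-fold lower number from compound 2 to compound 3 (0.10 log units; within the scatter) and leaves a 25-fold higher number from compound 1 to compound 3 (1.40 log units; beyond the scatter) on this aromatic carbon. An amine here is therefore not sufficient, since compound 3 departs from compound 1 in two features of one side chain: a methyl on the nitrogen and a methyl moved along the butyl chain. Nothing measured here explains the result.

Which of those two features accounts for the gap stays open. A 1-amino-3-methylbutyl group or a 2-methyl-1-(methylamino)butyl group would each carry only one of them.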